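The source may hold more compounds than are shown below. What is called first, only, known or untested is meant among the compounds shown, and "the series" means these compounds.

Working notes on the series. Within the data shown here, in a functional assay on SH-SY5Y cells (Homo sapiens) for cytotoxicity, read by MTT assay, with a stated time of 72 h (on this read-out lower numbers stand for stronger inhibition and higher numbers for weaker inhibition), compound 1 (`CN1CCN(CCCCn2c3c(c4ccccc42)C(=O)c2c[n+]([O-])c4ccccc4c2C3=O)CC1`) gives 100 nM, while compound 2 (`O=C1c2c[n+]([O-])c3ccccc3c2C(=O)c2c1c1ccccc1n2CCCCN1CCNCC1`) gives 1240 nM, the higher of the two numbers so far. Compound 3 (`O=C1c2c[n+]([O-])c3ccccc3c2C(=O)c2c1c1ccccc1n2CCCCN1CCCCC1`) is next, with piperidin-1-yl in place of piperazin-1-yl on a saturated chain carbon, four bonds along the chain from an aromatic nitrogen. In words, this is piperidin-1-yl in place of piperazin-1-yl on a saturated chain carbon, four bonds along the chain from an aromatic nitrogen. Among the measured compounds shown here, one measured step bears on it: a 12-fold higher number from compound 1 to compound 2 (1.09 log units; beyond the scatter), a large step on swapping methyl for hydrogen on an amine nitrogen in a ring. Compound 3, like compound 1, lacks that hydrogen, but this single step is thin support and the ring itself also changes. A sizeable step to a lower number in this assay is therefore expected, probably smaller than the measured one. The expected change is a 4.4-fold lower number from compound 2 to compound 3 (0.65 log units; beyond the scatter). For compound 3 the estimated value is 280 nM, with an expected range of 90 nM to 900 nM.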

Compound 3, half-maximal inhibitory concentration: 230 nM
Estimate against measurement, compound 3: 1.2-fold (0.09 log units) above; low and high end bracket the measured number.
By their numbers in this assay, from the lowest: compound 1; then compound 3; then compound 2.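

In this assay, among these compounds, the change at this position gives a 5.4-fold lower number from compound 2 to compound 3 (0.73 log units; beyond the scatter), so a low number here does not depend on the methyl group: piperidin-1-yl, which has no ring hydrogen-bond donor and only one ring nitrogen, also moves the number well down from that of the piperazin-1-yl compound. The remaining gap is a 2.3-fold higher number from compound 1 to compound 3 (0.36 log units; beyond the scatter), which leaves 4-methylpiperazin-1-yl with the lowest number of the three groups at this position, so removing the donor does not by itself match that group. Nothing measured on these compounds accounts for either step.

On these data alone, it remains open whether morpholin-4-yl, with an oxygen in the ring, or 4-ethylpiperazin-1-yl would fall nearer to 4-methylpiperazin-1-yl or to piperazin-1-yl. As far as these compounds go, how these ring groups would behave on a shorter or longer chain also remains open.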